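Removing a Methyl from a Low-Toxicity Ether Compound

The compounds below may be only part of what the source reports. "The series", "measured", "known", "first", "only" and "open" are said of these compounds alone.

Compound 1 `Cc1cc(-c2ccc(C#N)cc2)cc(Cl)c1Oc1ccnc(Nc2ccc(C#N)cc2)n1` was tested in a functional assay on MT4 cells (Homo sapiens) for cytotoxicity, read by MTT assay, with a stated time of 5 days; on this read-out lower numbers stand for higher toxicity in this test and higher numbers for lower toxicity in this test. In this test compound 1 reaches only a limit of the assay, > 285000 nM. Compound 2 `N#Cc1ccc(Nc2nccc(Oc3ccc(-c4ccc(C#N)cc4)c(F)c3)n2)cc1` likewise stops at a limit, > 307000 nM. Compound 3 `Cc1cc(-c2ccc(C#N)cc2)ccc1Nc1ccnc(Nc2ccc(C#N)cc2)n1` gives a measured value of 9200 nM in this assay. Compound 1 thus stands at the limit of > 285000 nM in this assay, at which 1 of the 3 values shown sits, one of two limits among the three values shown. Compound 4 `N#Cc1ccc(Nc2nccc(Oc3ccc(-c4ccc(C#N)cc4)cc3Cl)n2)cc1` differs from compound 1 in one way: hydrogen in place of methyl on an aromatic carbon. Going by the values given here, no measured pair in this set shows the effect of such a change, and the change is small. The expected step that the limit leaves unreadable from compound 1 to compound 4 is none beyond the scatter. The estimate for compound 4 in this assay is 300000 nM, with a range from 100000 nM to 600000 nM, and most likely again only a limit.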

Compound 4, half-maximal cytotoxic concentration: > 295000 nM
Compound 4 gave a limit, no number; the forecaster's own chance of this, stated with the estimate: 80%; the middle value is on the limit's open side.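

Going by these compounds alone, compound 1 and compound 4 both end at a limit rather than a number, so no step between them can be read. On these data alone, whether swapping methyl for hydrogen changes toxicity at all remains open.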